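The compounds below may be only part of what the source reports. "The series", "measured", "known", "first", "only" and "open" are said of these compounds alone.

Measured so far in an in vitro ADME assay on microsomes from liver (Homo sapiens) for metabolic stability, tested at 1 uM; on this read-out higher numbers stand for a longer-lived compound and lower numbers for a shorter-lived compound:
- compound 1 `CS(=O)(=O)Nc1ccc2c(c1)S(=O)(=O)N=C(C1=C(O)[C@@H]3[C@H]4CC[C@H](C4)[C@@H]3N(Cc3ccccc3F)C1=O)N2`: > 1 h
- compound 2 `CS(=O)(=O)Nc1ccc2c(c1)S(=O)(=O)N=C(C1=C(O)[C@@H]3[C@H]4CC[C@H](C4)[C@@H]3N(Cc3ccc(F)c(Cl)c3)C1=O)N2`: > 1 h
- compound 3 `CS(=O)(=O)Nc1ccc2c(c1)S(=O)(=O)N=C(C1=C(O)[C@@H]3[C@@H]4CC[C@@H](C4)[C@@H]3N(Cc3ccccc3F)C1=O)N2`: > 1 h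

Within the data shown here, none of these three entries is an exact number, and the whole series so far is defined by the limit of > 1 h in this assay, at which 3 of the 3 values shown sit. Compound 3 is known only through its limit of > 1 h.

Compound 4 `CS(=O)(=O)Nc1ccc2c(c1)S(=O)(=O)N=C(C1=C(O)[C@@H]3[C@@H]4CC[C@@H](C4)[C@@H]3N(Cc3ccc(F)c(Cl)c3)C1=O)N2` keeps the configuration of compound 3 and changes one group: 3-chloro-4-fluorophenyl in place of 2-fluorophenyl on a saturated chain carbon bound to an amide-type nitrogen in a ring. In words, this is 3-chloro-4-fluorophenyl in place of 2-fluorophenyl on a saturated chain carbon bound to an amide-type nitrogen in a ring.

The same swap on the other configuration gives a step that the two limits leave unreadable from compound 1 to compound 2. Changing the configuration alone, the case of the fact that compounds 1 and 3 differ only in the configuration as drawn, gives a step that the two limits leave unreadable from compound 1 to compound 3. Neither step has a readable size or direction, so no change beyond the usual scatter is expected in this assay. Among the measured compounds shown here, the closest precedent, compound 2, also rests on a limit of > 1 h.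

The expected change is a step that the limit leaves unreadable from compound 3 to compound 4. The estimate for compound 4 is 2 h, with an expected range from 1 h to 5 h.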

Compound 4, half-life: > 1 h
Compound 4 gave a limit, no number; the forecaster's own chance of this, stated with the estimate: 85%; the middle value is on the limit's open side.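

The step from compound 3 to compound 4 and the step from compound 2 to compound 4 cannot be read: in this assay, all three compounds give only a limit, not a number. The compounds shown leave open each compound's actual half-life, and whether the 3-chloro-4-fluorophenyl swap or the configuration changes it at all.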